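The source may hold more compounds than are shown below. What is called first, only, known or untested is meant among the compounds shown, and "the series" means these compounds.

Measured in a functional assay on HepG2 cells (Homo sapiens) for antiproliferative activity, read by XTT assay, with a stated time of 72 h (a lower number here means a stronger inhibitor, a higher number a weaker inhibitor), so far
Compound 1 `CNc1ncnc2c1c(-c1ccco1)cn2[C@@H]1O[C@H](CO)[C@@H](O)[C@H]1O` - 850 nM
Compound 2 `CN(C)c1ncnc2c1c(-c1ccsc1)cn2[C@@H]1O[C@H](CO)[C@@H](O)[C@H]1O` - > 20000 nM (a limit of the assay, not a number)
Compound 3 `C#Cc1cn([C@@H]2O[C@H](CO)[C@@H](O)[C@H]2O)c2ncnc(C)c12` - 290 nM

Only two of these results are numbers. Compound 1 has the higher number at 850 nM and so is the weaker inhibitor of the two. Compound 3 lies lower at 290 nM and the gap between them is beyond the usual scatter. Compound 2 gives only a limit of the assay at > 20000 nM and has no numeric position.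

Compound 4 `CNc1ncnc2c1c(I)cn2[C@@H]1O[C@H](CO)[C@@H](O)[C@H]1O` is still unmeasured. It has iodo in place of furan-2-yl on an aromatic carbon and otherwise keeps the structure of compound 1.

Going by the values given here, no step between measured compounds isolates this change, so the expectation is loose. Compound 3 at 290 nM also carries no ring at that place, although it differs from compound 1 elsewhere too. A small move toward a lower number is therefore expected in this assay and may not clear the scatter. The estimated change is a 1.7-fold lower number from compound 1 to compound 4 (0.23 log units; within the scatter) and it remains uncertain in size and direction.

For compound 4 the expected value is 500 nM with an estimated range from 80 nM to 3500 nM.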

Compound 4, half-maximal inhibitory concentration: > 20000 nM
Compound 4 gave a limit, no number; the forecaster's own chance of this, stated with the estimate: 10%; at least 40-fold (1.60 log units) between middle value and limit.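

In this assay, going by these compounds alone, iodo in place of furan-2-yl on this aromatic carbon gives the one step that isolates this position: an at least 23-fold higher number from compound 1 to compound 4 (1.37 log units; beyond the scatter). Compound 4 stands at > 20000 nM, which is a limit of the assay and not a number. This place on the shared core is therefore not indifferent to its substituent: with everything else kept as in compound 1, the five-membered aromatic ring goes with a measured value and the single iodine atom does not, and the step gives only a lower bound on the change, its true size being unreadable at this ceiling: the limit of > 20000 nM in this assay, at which 2 of the 4 values shown sit.

The compounds shown do not separate the loss of the ring from the entry of iodo, and compound 3, with ethynyl at this place, differs from compound 1 elsewhere too and so gives no step. From the compounds shown here alone, whether any group without a ring is tolerated here stays open; chloro, an amine or a phenyl ring at this carbon on the core of compound 1 would bear directly on that question.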